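The compounds below may be only part of what the source reports. "The series", "measured", "known", "first", "only" and "open" are said of these compounds alone.

Measured compounds:
Compound 1 `N#CSc1cn([C@H]2C[C@H](O)[C@@H](CO)O2)c(=O)[nH]c1=O` gives 78900 nM in an ADME assay on L1210/0 cells (Mus musculus) for cytotoxicity, with a stated time of 48 h; on this read-out higher numbers stand for weaker inhibition and lower numbers for stronger inhibition.
Compound 2 `OC[C@H]1CCC[C@@H]1n1cnc2c(Cl)ncnc21` gives only a limit of the assay, > 200000 nM, in this assay.

Within the data shown here, compound 1 therefore stands as the only real number in this assay; the second value is a limit, not a measurement. That limit, (the limit of > 200000 nM in this assay, at which 1 of the 2 values shown sits), means compound 2 gave no number within the range of the assay.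

Compound 3 `O=c1[nH]c(=O)n([C@H]2C[C@H](O)[C@@H](CO)O2)cc1/C=C/Cl` has not yet been measured. It differs from compound 1 in one place: 2-chloroethenyl in place of cyanosulfanyl on an aromatic carbon. Among the measured compounds shown here, no step between two measured compounds exists in this set, so there is nothing against which the size of such a change can be gauged. The expected step from compound 1 to compound 3 is a 1.5-fold higher number from compound 1 to compound 3 (0.18 log units; within the scatter), small and close to the scatter, with a slight lean toward weaker inhibition. Compound 3 is estimated to give 120000 nM in this assay, within a range from 40000 nM to 400000 nM.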

Compound 3, half-maximal inhibitory concentration: > 200000 nM
Compound 3: no number, only a limit; the forecaster's own chance of this, stated with the estimate: 35%; at least 1.6-fold (0.22 log units) between middle value and limit.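

In this assay, among these compounds, there is an at least 2.5-fold higher number from compound 1 to compound 3 (0.40 log units; beyond the scatter) when 2-chloroethenyl takes the place of cyanosulfanyl on this aromatic carbon, the first step at this position that can be read. The group at this position therefore matters for the read-out, and of these two groups only cyanosulfanyl gives a real number. Going by these compounds, the value for compound 3 is a limit, so the true size of the step stays unknown, and limits are common in this small set: the limit of > 200000 nM in this assay, at which 2 of the 3 values shown sit.

The compounds shown leave open whether another group at this position, such as an amine, a carboxylic acid or a longer chain, would give a lower number than compound 1 does. Among the compounds shown here, with only one change readable here, no trend across groups can be drawn.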